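Cyano for Chloro on the Carboxylic Acid Analogue

The source may report more compounds than this note shows. Statements on the series, on what has been measured and on what is new or still open speak of the compounds shown alone.

The measured compounds are: compound 1 `CCOC(=O)C(=O)CC(=O)/C=C/c1cn(Cc2ccc(Cl)cc2)c2ccccc12`, which in an assay on isolated protein for inhibition of DNA nucleotidylexotransferase (Homo sapiens), read by scintillation counting, with a stated time of 10 min (on this read-out higher numbers stand for weaker inhibition and lower numbers for stronger inhibition), gives 40 uM. Compound 2 `CCOC(=O)C(=O)CC(=O)/C=C/c1cn(Cc2ccc(C#N)cc2)c2ccccc12` reaches only the limit of this assay, > 40 uM. Compound 3 `O=C(/C=C/c1cn(Cc2ccc(Cl)cc2)c2ccccc12)CC(=O)C(=O)O` gives 10 uM.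

Compound 3 differs from compound 1 by hydrogen in place of ethyl on an oxygen next to a carbonyl group, a change that gave a 4.0-fold lower number from compound 1 to compound 3 (0.60 log units; beyond the scatter). Compound 2 differs from compound 1 by cyano in place of chloro on an aromatic carbon, a change that gave a number no lower from compound 1 to compound 2 (the limit leaves the size open); the size is open because of the limit of > 40 uM in this assay, at which 1 of the 3 values shown sits.

Compound 4 `N#Cc1ccc(Cn2cc(/C=C/C(=O)CC(=O)C(=O)O)c3ccccc32)cc1` is not yet measured. It differs from compound 3 by cyano in place of chloro on an aromatic carbon, the same change as from compound 1 to compound 2, at the same place. From that earlier step, compound 4 is expected to give a 3.0-fold higher number from compound 3 to compound 4 (0.48 log units; beyond the scatter), with the size uncertain. Compound 4 is therefore estimated at 30 uM, within 12 uM to 80 uM.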

Compound 4, concentration for 50% inhibition: 1.4 uM
For compound 4 the middle estimate is 21-fold (1.33 log units) above the measured one, and the stated range ends above it.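

On the core of compound 3, cyano in place of chloro gave a 7.1-fold lower number from compound 3 to compound 4 (0.85 log units; beyond the scatter) in this assay, whereas on the core of compound 1 it gave a number no lower from compound 1 to compound 2 (the limit leaves the size open), so the step did not carry over unchanged from one core to the other: the same change on two cores in this assay, a number no lower (the limit leaves the size open) from compound 1 to compound 2 and a 7.1-fold lower number (0.85 log units; beyond the scatter) from compound 3 to compound 4, at least 7.1-fold (0.85 log units) apart, beyond the scatter of two such steps. Hydrogen in place of ethyl also differed with its partner, with an at least 28-fold lower number from compound 2 to compound 4 (1.45 log units; beyond the scatter) set against a 4.0-fold lower number from compound 1 to compound 3 (0.60 log units; beyond the scatter): the same change on two cores in this assay, a 4.0-fold lower number (0.60 log units; beyond the scatter) from compound 1 to compound 3 and an at least 28-fold lower number (1.45 log units; beyond the scatter) from compound 2 to compound 4, at least 7.1-fold (0.85 log units) apart, beyond the scatter of two such steps. Compound 2 gives > 40 uM, which is a limit of the assay, so these comparisons fix no exact gap between the steps, and two pairs show nothing about further cores.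

The compounds shown leave open how an amine or a nitro group in place of the cyano group would behave. They also leave open whether an amide in place of the carboxylic acid would keep the number of compound 4.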